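The source may hold more compounds than are shown below. What is called first, only, known or untested is meant among the compounds shown, and "the series" means these compounds.

This small series shares one core and was examined in a toxicity assay on THP-1 cells (Homo sapiens) for inhibition; on this read-out higher numbers stand for lower toxicity in this test and lower numbers for higher toxicity in this test. Going by the values given here, compound 1 (`Cn1c(-c2ccccc2Cl)cnc1NC(=O)c1ccc(F)cc1`) is the first member. In this assay compound 1 reaches only a limit of the test, > 50000 nM, and no number. Compound 2 (`COc1ccc(-c2cnc(NC(=O)c3ccco3)n2C)cc1`) carries a furan-2-yl group on its carbonyl carbon. In this assay compound 2 likewise gives only a limit, > 100000 nM. Compound 3 (`COc1ccc(-c2cnc(NC(=O)c3ccc(F)cc3)n2C2CCCC2)cc1`) also stops at a limit in this assay, > 100000 nM. Compound 2 therefore stands where most of the series stands, at the limit of > 100000 nM in this assay, at which 2 of the 3 values shown sit. Compound 1 alone sits at the limit of > 50000 nM in this assay, at which 1 of the 3 values shown sits. Since none of the three values is a real number, no measured step between any two of them can be counted, and no cause for any difference can be named.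

Compound 4 (`COc1ccc(-c2cnc(NC(=O)c3cccc(C)c3)n2C)cc1`) has not yet been tested. It differs from compound 2 in one place: 3-methylphenyl in place of furan-2-yl on a carbonyl carbon. Every measured member has stayed at a limit, and compound 2 in particular gives only > 100000 nM in this assay, so the expected step in this assay is a number no higher from compound 2 to compound 4 (the limit leaves the size open), no movement beyond the usual scatter. Compound 4 is thus estimated at 100000 nM in this assay, with a likely range from 30000 nM to 300000 nM, and it is expected that the test will again report only a limit rather than a number.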

Compound 4, half-maximal cytotoxic concentration: > 100000 nM
Compound 4: no number, only a limit (the forecaster's own chance of this, stated with the estimate: 85%); the middle value sits exactly at the limit.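

Compound 2 and compound 4 both stop at a limit of the test in this assay, not at a number. The step between them, 3-methylphenyl in place of furan-2-yl on a carbonyl carbon, cannot be read. The compounds shown leave open what real value any of them would give in this assay, and whether any change of group moves it.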